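This account rests on a few compounds, and the source may have more. Where it says the series, first, only, none or still open, it means among the compounds named here.

Working notes on the series.

Of the compounds shown here, three of the shared core have been measured in a functional assay on isolated protein for inhibition of Glucose-dependent insulinotropic receptor (Homo sapiens), read by HTRF and cAMP accumulation; on this read-out higher numbers stand for an effect only at larger amounts of compound and lower numbers for an effect already at smaller amounts. Compound 1 `Cc1nc(S(C)(=O)=O)ccc1Oc1ncnc(OC2CCN(C(=O)OC(C)(C)C#N)CC2)c1F` gives 92.9 nM, compound 2 `Cc1nc(S(C)(=O)=O)ccc1Oc1ncnc(OC2CCN(C(=O)SC(C)C)CC2)c1F` gives 6.8 nM and compound 3 `Cc1nc(S(C)(=O)=O)ccc1Oc1ncnc(OC2CCN(C(=O)SC3CC3)CC2)c1F` gives 24.9 nM. Compound 3 thus stands second of the three numbers: a 3.7-fold lower number from compound 1 to compound 3 (0.57 log units; beyond the scatter), while a 3.7-fold higher number from compound 2 to compound 3 (0.56 log units; beyond the scatter).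

Compound 4 `Cc1nc(S(C)(=O)=O)ccc1Oc1ncnc(OC2CCN(C(=S)OC(C)C)CC2)c1F` is to be measured next. The change from compound 3 is a group of 6 heavy atoms (4 carbon, 1 oxygen, 1 sulfur; no ring) in place of a group of 6 heavy atoms (4 carbon, 1 oxygen, 1 sulfur; one three-membered non-aromatic ring of carbon only), on an amine nitrogen in a ring. It is not a single-point change: the three-membered ring gives way to the isopropyl group, and the sulfur and oxygen of the attached group exchange places. Only the first part has a measured counterpart, a 3.7-fold higher number from compound 2 to compound 3 (0.56 log units; beyond the scatter), so reversing the ring-to-isopropyl part alone would be expected to lower the number by about that step. For the measured compounds named here, for the swap of sulfur and oxygen no measured pair exists, so its size is open.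

Weighing the one step that bears on it, compound 4 is expected to give 10 nM (range 3 nM to 40 nM), an expected step of a 2.5-fold lower number from compound 3 to compound 4 (0.40 log units; beyond the scatter) and close to compound 2.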

Compound 4, half-maximal effective concentration: 69.9 nM
Compound 4: middle estimate off by 7.0-fold (0.84 log units), on the low side; measured number above the stated range.
By their numbers in this assay, from the lowest: compound 2; then compound 3; then compounds 4 and 1 (each within the scatter of the next).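

In this assay the exchange of sulfur and oxygen with the isopropyl group kept gives a 10-fold higher number from compound 2 to compound 4 (1.01 log units; beyond the scatter) and is a large step, so on this amine nitrogen the placing of the two atoms in the attached group counts for more than the cyclopropyl-to-isopropyl change seen earlier. The combined change gives a 2.8-fold higher number from compound 3 to compound 4 (0.45 log units; beyond the scatter) in the same direction, so isopropyl does not bring a low number by itself here, and a 1.3-fold lower number from compound 1 to compound 4 (0.12 log units; within the scatter) leaves compound 4 undistinguished from the 1-cyano-1-methylethoxy group of compound 1. No measurement at hand accounts for the effect of the exchange.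

From the compounds shown here alone, it stays open whether the step between isopropyl and cyclopropyl carries over to the thiocarbonyl form, which a cyclopropyloxy thiocarbonyl group would test. A plain isopropyl carbamate, with oxygen in both places, also remains to be placed against these numbers.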